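This account rests on a few compounds, and the source may have more. Where it says the series, first, only, none or still open, it means among the compounds named here.

Measured compounds:
- compound 1, `Cc1ccc(NS(=O)(=O)C2CCCCC2=O)c(C)c1`, in a functional assay on Bel-7402 cells (Homo sapiens) for antiproliferative activity, read by sulforhodamine B assay, tested at 100 ug/mL (on this read-out higher numbers stand for more inhibition at the one concentration tested (going by the name of the read-out) and lower numbers for less inhibition), compound 1 gives 0.52%
- compound 2, `O=C1CCCCC1S(=O)(=O)Nc1ccc(Cl)cc1`, in this assay compound 2 gives 4.47%
- compound 3, `O=C1CCCCC1S(=O)(=O)Nc1ccc(Cl)c(Cl)c1`, in this assay compound 3 gives 1.39%

All three numbers are small and lie within the scatter of one another. Compound 2 carries the highest number of the three as written, but its gap to compound 3 and its gap to compound 1 are both within the scatter, so no ordering can be read from them.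

The next compound, compound 4, `Cc1ccc(NS(=O)(=O)C2CCCCC2=O)cc1`, differs from compound 2 in one place: methyl in place of chloro on an aromatic carbon.

Within the data shown here, only one measured step exists, and it touches the same ring from another side: a number 3.1 percentage points lower from compound 2 to compound 3 (within the scatter), a change that left the number within the scatter. Among the measured compounds shown here, no measured pair shows methyl in place of chloro directly. Compound 1, which carries methyl groups rather than chloro, gives a number in the same low region as compound 2 and compound 3. On this basis no step beyond the scatter is expected in this assay for compound 4, in either direction.

Compound 4 is therefore estimated at 3%, with a range from 0% to 12%, which amounts to an expected step of a number 1.5 percentage points lower from compound 2 to compound 4 (within the scatter).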

Compound 4, a percentage reported as inhibition, at one concentration (the size of the read-out at that concentration, not a potency): 27.5%
The estimate for compound 4 lay 24.5 percentage points below the measured number, outside the stated range (above it).
By their numbers in this assay, from the lowest: compounds 1, 3 and 2 (each within the scatter of the next); then compound 4.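

In this assay, the aromatic carbon para to a large group proves to be a place where the number can move: methyl in place of chloro there gives a number 23 percentage points higher from compound 2 to compound 4 (beyond the scatter), the first step among these compounds beyond the scatter, whereas adding a second chloro group to compound 2 had left the number within it. Hydrogen in place of methyl on an aromatic carbon gives a number 27 percentage points higher from compound 1 to compound 4 (beyond the scatter), so the higher number is not shared by every methyl-bearing compound shown and depends on more than the presence of a methyl group on the ring. Nothing available explains why either change has a step of this size.

The compounds shown leave open whether the higher number is particular to methyl at the para carbon, or would also appear with hydrogen, a longer chain such as ethyl, a methoxy group or an amine in that place. They also leave open how compound 4 would behave at other concentrations, since a single-concentration reading gives the size of the inhibition at that concentration and not a potency.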